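The source may hold more compounds than are shown below. What is called first, only, known or untested is meant among the compounds shown, and "the series" means these compounds.

Series notes, an assay on membranes from HeLa cells for displacement of a labelled ligand from adenosine receptor A3 (Homo sapiens), read by scintillation counting, with a stated time of 180 min, tested at 1 uM; on this read-out higher numbers stand for more inhibition at the one concentration tested (going by the name of the read-out) and lower numbers for less inhibition. Compound 1 `CCCOC(=O)C1=C(C)NC(=O)NC1c1ccsc1` gives 6%; compound 2 `CC1=C(C(=O)CC(C)C)C(c2ccoc2)NC(=O)N1` gives 18%; compound 3 `CCCC(=O)C1=C(C)NC(=O)NC1c1ccsc1` gives 1%. Among the measured compounds shown here, compound 3 has the lowest of the three numbers, but the nearest, compound 1, sits within the scatter of it, since the step of a number 5 percentage points lower from compound 1 to compound 3 (within the scatter) is within the scatter; the furthest is compound 2, whose number stands beyond the scatter above that of compound 3, though these two differ in more than one place and no single step connects them.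

The next compound, compound 4 `CC1=C(C(=O)CC(C)C)C(c2ccsc2)NC(=O)N1`, differs from compound 3 by methyl in place of hydrogen on a saturated chain carbon bound to two saturated chain carbons. For the measured compounds named here, only one measured step exists in this assay, a number 5 percentage points lower from compound 1 to compound 3 (within the scatter), and it concerns a different change, propyl in place of propoxy on a carbonyl carbon; it was within the scatter. Compound 2 carries the same isobutylcarbonyl as compound 4 but a different ring, so its number cannot be read as a step for this change. Going by the values given here, nothing among the measured compounds therefore argues for a step beyond the scatter in this assay; a small change in either direction is the expectation. Compound 4 is estimated at 5%, range 0% to 15%, meaning an expected step of a number 4 percentage points higher from compound 3 to compound 4 (within the scatter).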

Compound 4, a percentage reported as inhibition, at one concentration (the size of the read-out at that concentration, not a potency): 14%
For compound 4 the middle estimate is 9 percentage points below the measured one; the measured number falls inside the stated range.
By their numbers in this assay, from the lowest: compounds 3, 1, 4 and 2 (each within the scatter of the next, the first and the last beyond it).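

In this assay, among the compounds shown here, the branch on the chain gives the first single-place step beyond the scatter: methyl in place of hydrogen on a saturated chain carbon bound to two saturated chain carbons, which reads as propylcarbonyl to isobutylcarbonyl, gives a number 13 percentage points higher from compound 3 to compound 4 (beyond the scatter) and so shows that this position responds to a change of a single carbon. The two other comparisons do not resolve anything further, since thiophen-3-yl in place of furan-3-yl on a saturated ring carbon gives a number 4 percentage points lower from compound 2 to compound 4 (within the scatter) and replacing the propoxy by an isobutyl gives a number 8 percentage points higher from compound 1 to compound 4 (within the scatter) with the thiophen-3-yl ring held. Nothing measured on these compounds bears on what lies behind the step.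

On these data alone, whether the same methyl step holds with furan-3-yl in place of thiophen-3-yl stays open. Also open, as far as these compounds go, is whether a longer chain such as pentyl, a cyclohexyl or an amine on the same carbonyl carbon moves the number further, and what potency lies behind any of these single-concentration numbers.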